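Changing the Ring on Compound 2

This account rests on a few compounds, and the source may have more. Where it says the series, first, only, none or still open, it means among the compounds named here.

In an ADME assay on microsomes from liver (Mus musculus) for metabolic stability, read by LC-MS, using NADPH, with a stated time of 10 min, tested at 10 uM (on this read-out higher numbers stand for a longer-lived compound and lower numbers for a shorter-lived compound), compound 2 `Nc1ncnc2c1c(Oc1cc(C(F)(F)F)ccn1)nn2[C@H]1CC[C@@H](N)CC1` gives 0.917 h, the higher of the two exact numbers available. Compound 1 `Cc1cccc(Oc2nn(C(C)(C)C)c3ncnc(N)c23)c1` gives 0.0717 h, lower than compound 2 by well beyond the usual scatter. Compound 3 `N#Cc1ccnc(Oc2nn([C@H]3C[C@H](O)C3)c3ncnc(N)c23)c1` gives > 2.41 h, which is a limit of the assay and not a number.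

Compound 4 `Nc1ncnc2c1c(Oc1cc(C(F)(F)F)ccn1)nn2C1CCC(O)C1` differs from compound 2 in one place: 3-hydroxycyclopentyl in place of 4-aminocyclohexyl on an aromatic nitrogen. In words, it has 3-hydroxycyclopentyl in place of 4-aminocyclohexyl on an aromatic nitrogen. For the measured compounds named here, no measured pair shows this change alone, so its size in this assay can only be judged loosely. Going by the values given here, the one guide is compound 3, which also carries a hydroxy-bearing ring on that nitrogen and whose > 2.41 h is a limit. Its other aromatic group differs as well, so this guide is weak. The expected change is small, a 1.4-fold higher number from compound 2 to compound 4 (0.15 log units; within the scatter), a slight rise that stays within the scatter. For compound 4 the estimated half-life is 1.3 h, with an expected range of 0.45 h to 3 h.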

Compound 4, half-life: 0.3 h
Estimate against measurement, compound 4: 4.3-fold (0.64 log units) above; measured number below the stated range.
By their numbers in this assay, from the lowest: compound 1; then compound 4; then compound 2. At a limit, above all of these: compound 3.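

In this assay, the group on the aromatic nitrogen clearly affects half-life: with the rest of the molecule unchanged, putting 3-hydroxycyclopentyl in place of 4-aminocyclohexyl gives a 3.1-fold lower number from compound 2 to compound 4 (0.49 log units; beyond the scatter). For the compounds shown here, this is the first step in which only this one position changes, so the earlier compounds, which differ from each other in more than one place, could not show it. A ring bearing a hydroxy group at this position therefore does not in itself bring a long half-life, and nothing shown here explains the drop.

Going by these compounds, this change alters the ring size and swaps the amine for a hydroxy group at the same time, so it remains open which of the two matters. A cyclohexyl ring bearing a hydroxy group, or a cyclopentyl ring bearing an amine, on the same nitrogen would separate the two.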